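Purine series: amino removal at the core of compound 1

The compounds below may be only part of what the source reports. "The series", "measured", "known", "first", "only" and "open" are said of these compounds alone.

Measured in a functional assay on HCT-15 cells (Homo sapiens) for cytotoxicity, read by sulforhodamine B assay, with a stated time of 48 h (a lower number here means a stronger inhibitor of growth, a higher number a weaker inhibitor of growth), so far:

Compound 1, `Nc1nc(Cl)c2ncn(Cc3ccccc3CCl)c2n1`: 2700 nM
Compound 2, `ClCc1ccccc1Cn1cnc2nc(Cl)nc(Cl)c21`: 190 nM
Compound 3, `ClCc1ccc(Cn2cnc3c(Cl)nc(Cl)nc32)cc1`: 1860 nM

Compound 1 gives the highest of the three numbers in this assay. Its nearest neighbour is compound 3, whose number sits within the usual scatter of compound 1, so no order between the two can be read. Compound 2 gives a number far below that of compound 1, beyond the scatter. Within the data shown here, no pair of these three differs in one place only, so none of the gaps between them can be assigned to a single structural change.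

Compound 4, `ClCc1ccccc1Cn1cnc2c(Cl)ncnc21`, is not yet measured. It differs from compound 1 in one place: hydrogen in place of amino on an aromatic carbon. The change sits on the core shared by all compounds here, on an aromatic carbon of the six-membered aromatic ring with 2 nitrogen, between two ring nitrogen atoms and meta to a chloro group.

Nothing measured here isolates the contribution of the amino group, so the expected step from compound 1 to compound 4 is taken as modest. The expected movement is a 1.8-fold lower number from compound 1 to compound 4 (0.26 log units; within the scatter), a step of uncertain direction that may well fall within the scatter. Compound 4 is estimated at 1500 nM, with a plausible range from 400 nM to 6000 nM.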

Compound 4, concentration for 50% growth inhibition: 2090 nM
Beside the measured number, compound 4's estimate is 1.4-fold (0.14 log units) below it; the range from low to high includes it.
By their numbers in this assay, from the lowest: compound 2; then compounds 3, 4 and 1 (each within the scatter of the next).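

In this assay, among these compounds, hydrogen in place of amino on the aromatic carbon between two ring nitrogen atoms gives a 1.3-fold lower number from compound 1 to compound 4 (0.11 log units; within the scatter), and this is the only comparison so far that isolates a single structural change. The amino group leaves with its hydrogen-bond donor and acceptor, yet the step stays within the scatter, so the data show no measurable gain or loss from this exchange on the core of compound 1 and give this amino group no demonstrated part in the growth inhibition read here. No measured property of these compounds bears on the size of this step.

From the compounds shown here alone, whether other groups on this aromatic carbon, such as a methoxy, a dimethylamino or a hydroxyl group, would also leave the number within the scatter remains open, as does whether the same exchange would behave alike with the chloromethyl group of compound 3. The number of compound 2 still has no single-place link to any other compound here, so its gap to the others cannot be read as the result of one change.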